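A few compounds are considered here, and "the series" means these few. Any claim that something is new, unique, unknown or untested is made for them only; others in the source may bear on it.

Compound 1 `NC(=O)CCCC/C=C(\c1ccccc1)c1cccnc1` and compound 2 `O=C(O)C(CCC/C=C(\c1ccccc1)c1cccnc1)C1=CCCC1` share a core that carries a phenyl group and a pyridine ring on a double bond, and they differ in what hangs at the end of the chain. In an assay (Equus caballus) for inhibition of Thromboxane-A synthase (Homo sapiens), using microsomes (a higher number here means a weaker inhibitor, a lower number a stronger inhibitor), compound 1 gives 400 nM, and in this assay compound 2 gives 60 nM, so compound 2 stands at the lower of the two numbers, with the gap to compound 1 beyond the scatter of repeated measurements. Compound 3 `COCC(CCC/C=C(\c1ccccc1)c1cccnc1)C(=O)O` keeps the acid of compound 2 and changes one group: methoxymethyl in place of cyclopent-1-en-1-yl on a saturated chain carbon bound to a carbonyl carbon and a saturated chain carbon. Among the measured compounds shown here, no measured pair shows the effect of such a swap on its own, so the direction is not fixed by the data. The change from compound 2 to compound 3 is estimated at a 2.0-fold higher number from compound 2 to compound 3 (0.30 log units; within the scatter), a modest rise that could still fall within the scatter. For compound 3 the expected value in this assay is 120 nM, with a range from 40 nM to 400 nM.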

Compound 3, half-maximal inhibitory concentration: 41 nM
Estimate against measurement, compound 3: 2.9-fold (0.47 log units) above, within the range that was stated.
By their numbers in this assay, from the lowest: compounds 3 and 2 (each within the scatter of the next); then compound 1.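

In this assay, methoxymethyl in place of cyclopent-1-en-1-yl on a saturated chain carbon bound to a carbonyl carbon and a saturated chain carbon gives a 1.5-fold lower number from compound 2 to compound 3 (0.17 log units; within the scatter), the first step read at this position, so here the ring can give way to an open group with fewer heavy atoms and one hydrogen-bond acceptor without a change beyond the scatter. The replacement of carbamoylmethyl by 1-carboxy-2-methoxyethyl on a saturated chain carbon, three bonds along the chain from a double-bonded chain carbon, gives a 9.8-fold lower number from compound 1 to compound 3 (0.99 log units; beyond the scatter), a step that brings in the acid and the methoxymethyl branch together. No measurement offers an explanation for either step.

From the compounds shown here alone, how far the acid and the branch each contribute remains open. So does the outcome with an amine or a hydroxymethyl group at this position.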